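The source may report more compounds than this note shows. Statements on the series, on what has been measured and on what is new or still open speak of the compounds shown alone.

Compound 1 `Cc1ccc(S(=O)(=O)NCc2cn(C[C@H](O)[C@H]3OC(=O)C(OCc4ccccc4)=C3OCc3ccccc3)nn2)cc1`: 24900 nM in a functional assay on HepG2 cells (Homo sapiens) for antiproliferative activity, read by MTT assay, with a stated time of 72 h; a higher number here means a weaker inhibitor, a lower number a stronger inhibitor
Compound 2 `O=C1O[C@H]([C@@H](O)Cn2cc(CNS(=O)(=O)c3ccc(F)cc3)nn2)C(OCc2ccccc2)=C1OCc1ccccc1`: 18300 nM in this assay
Compound 3 `O=C1O[C@H]([C@@H](O)Cn2cc(CNS(=O)(=O)c3ccc(Cl)cc3)nn2)C(OCc2ccccc2)=C1OCc1ccccc1`: 7510 nM in this assay

Compound 3 stands lowest of the three numbers. Its distance from compound 2, a 2.4-fold lower number from compound 2 to compound 3 (0.39 log units; beyond the scatter), and from compound 1, a 3.3-fold lower number from compound 1 to compound 3 (0.52 log units; beyond the scatter), both lie beyond the scatter, whereas a 1.4-fold lower number from compound 1 to compound 2 (0.13 log units; within the scatter) lies within it. Compound 4 `O=C1O[C@H]([C@@H](O)Cn2ccnn2)C(OCc2ccccc2)=C1OCc1ccccc1` differs from compound 3 in that (hydrogen in place of (((4-chlorophenyl)sulfonyl)amino)methyl on an aromatic carbon). Among the measured compounds shown here, none of the measured steps touches this change directly: each of them swaps one substituent on the aromatic ring of the group that now leaves, and those swaps moved the number by modest amounts at most. Removal of the whole arm is a larger change than any of them, and the data give no direct measure of what it contributes. Because compound 3 gives 7510 nM while compound 1 and compound 2, carrying other substituents on that same ring, give higher numbers, the identity of that ring does move the read-out, and losing the ring entirely is expected to raise the number. The estimate for compound 4 in this assay is 30000 nM, within a range from 8000 nM to 120000 nM. This expectation corresponds to a step of a 4.0-fold higher number from compound 3 to compound 4 (0.60 log units; beyond the scatter), carrying wide uncertainty.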

Compound 4, half-maximal inhibitory concentration: > 100000 nM
Compound 4 was reported as a limit; the forecaster's own chance of this, stated with the estimate: 25%; at least 3.3-fold (0.52 log units) between middle value and limit.
By their numbers in this assay, from the lowest: compound 3; then compounds 2 and 1 (each within the scatter of the next). At a limit, above all of these: compound 4.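

Compound 4 is reported in this assay only as a limit, not as a number: the limit of > 100000 nM in this assay, at which 1 of the 4 values shown sits.

The earlier compounds shown here varied only the substituent on the aromatic ring of the arm, whereas here the whole (((4-chlorophenyl)sulfonyl)amino)methyl group leaves the five-membered aromatic ring with 3 nitrogen and hydrogen takes its place, which gives an at least 13-fold higher number from compound 3 to compound 4 (1.12 log units; beyond the scatter). The arms with the other two ring substituents give an at least 5.4-fold higher number from compound 2 to compound 4 (0.73 log units; beyond the scatter) and an at least 4.0-fold higher number from compound 1 to compound 4 (0.60 log units; beyond the scatter), so with methyl, fluoro or chloro on its ring, each compound carrying the arm stands apart from compound 4 beyond the scatter, and the arm as a whole matters at this position more than the swaps on its ring had shown.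

The compounds shown leave open which part of the arm accounts for this, for instance whether a bare aminomethyl group on that aromatic carbon would retain any of the effect or whether the aromatic ring of the arm is required. As far as these compounds go, how far compound 4 actually lies past its limit also remains open, so the true size of these three steps is unknown.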